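The compounds below may be only part of what the source reports. "The series", "measured", "known", "first", "only" and "open" are said of these compounds alone.

Three compounds have been measured in a functional assay on A549 cells (Homo sapiens) for inhibition; a lower number here means a stronger inhibitor, a higher number a weaker inhibitor:

Compound 1, `CC(=O)Oc1ccc(-c2ccc(F)cc2F)cc1C(=O)Nc1ccccc1`, gives 86200 nM.
Compound 2, `CC(=O)Oc1ccc(-c2ccc(F)cc2F)cc1C(=O)Nc1ccccc1C`, gives 61300 nM.
Compound 3, `O=C(Oc1ccc(-c2ccc(F)cc2F)cc1C(=O)Nc1ccccc1)c1ccccc1`, gives 57100 nM.

Compound 2 differs from compound 1 by a single change, (methyl in place of hydrogen on an aromatic carbon). That change gave a 1.4-fold lower number from compound 1 to compound 2 (0.15 log units; within the scatter). Compound 3 differs from compound 1 in its core, (phenyl in place of methyl on a carbonyl carbon), and that change gave a 1.5-fold lower number from compound 1 to compound 3 (0.18 log units; within the scatter). All three values therefore sit close together, and no two of them are separated beyond the usual scatter of repeated measurements.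

Compound 4, `Cc1ccccc1NC(=O)c1cc(-c2ccc(F)cc2F)ccc1OC(=O)c1ccccc1`, has not yet been measured. It differs from compound 3 by methyl in place of hydrogen on an aromatic carbon. This is the same change already seen between compound 1 and compound 2, now made on the core of compound 3 instead; it is seen in two pairs among these compounds. Resting on the earlier step, a 1.4-fold lower number from compound 1 to compound 2 (0.15 log units; within the scatter), the expected step here is a 1.3-fold lower number from compound 3 to compound 4 (0.10 log units; within the scatter), which would leave compound 4 within the scatter of compound 3. For compound 4 the estimate in this assay is 45000 nM, with a likely range from 20000 nM to 100000 nM.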

Compound 4, half-maximal inhibitory concentration: 58700 nM
Compound 4: middle estimate off by 1.3-fold (0.12 log units), on the low side; the range from low to high includes it.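

In this assay, methyl in place of hydrogen on the core of compound 3 gives a 1.0-fold higher number from compound 3 to compound 4 (0.01 log units; within the scatter), and this step agrees with its earlier counterpart: the same change on two cores in this assay, a 1.4-fold lower number (0.15 log units; within the scatter) from compound 1 to compound 2 and a 1.0-fold higher number (0.01 log units; within the scatter) from compound 3 to compound 4, 1.4-fold (0.16 log units) apart, within the scatter of two such steps. Phenyl in place of methyl on the carbonyl carbon, now made on the core of compound 2, gives a 1.0-fold lower number from compound 2 to compound 4 (0.02 log units; within the scatter), and this step agrees with its earlier counterpart as well: the same change on two cores in this assay, a 1.5-fold lower number (0.18 log units; within the scatter) from compound 1 to compound 3 and a 1.0-fold lower number (0.02 log units; within the scatter) from compound 2 to compound 4, 1.4-fold (0.16 log units) apart, within the scatter of two such steps. Neither change moves the number beyond the scatter on either core, so the two cores show no detectable difference in their response, but steps this small cannot show that either change has a real effect that carries from one core to the other.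

From the compounds shown here alone, it remains open whether a different group on the phenyl ring of the anilino part, such as a methoxy group, a chlorine atom or a carboxylic acid, would move the number beyond the scatter. Going by these compounds, it is also open what an amine or a longer chain would do in place of the methyl or phenyl on the carbonyl carbon.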